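Chloro Added to Compound 2: Permeability Expectation

This account rests on a few compounds, and the source may have more. Where it says the series, first, only, none or still open, it means among the compounds named here.

Compound 2 `CCCCc1nc(=O)c(S(=O)(=O)c2ccc(-n3ccccc3=O)cc2)c(O)n1-c1c(OC)cccc1OC` gives 12 nm/s in an ADME assay for permeability, using PAMPA, at pH 5.5 (on this read-out lower numbers stand for lower permeability and higher numbers for higher permeability), the lowest of the two numbers shown. Within the data shown here, compound 1 `CCCCc1nc(=O)c(S(=O)(=O)c2ccc(-c3cccnc3)cc2)c(O)n1-c1c(OC)cccc1OC` gives 202 nm/s in this assay, and the step of a 17-fold lower number from compound 1 to compound 2 (1.23 log units; beyond the scatter) is the only measured step. Compound 3 `CCCCc1nc(=O)c(S(=O)(=O)c2ccc(-n3cc(Cl)ccc3=O)cc2)c(O)n1-c1c(OC)cccc1OC` differs from compound 2 by chloro in place of hydrogen on an aromatic carbon, a chloro in place of hydrogen on an aromatic carbon. Among the measured compounds shown here, no measured step bears on this change; the one step seen concerns a different group. For compound 3 a small rise is expected in this assay, a 1.8-fold higher number from compound 2 to compound 3 (0.26 log units; within the scatter), giving an estimate of 22 nm/s within 8 nm/s to 60 nm/s.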

Compound 3, apparent permeability: 83 nm/s
For compound 3 the middle estimate is 3.8-fold (0.58 log units) below the measured one; the measured number lies above the stated range.
By their numbers in this assay, from the lowest: compound 2; then compound 3; then compound 1.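

In this assay, chloro in place of hydrogen on this aromatic carbon, two atoms from the ring nitrogen, gives a 6.9-fold higher number from compound 2 to compound 3 (0.84 log units; beyond the scatter) and so shows that this position responds to a single added heavy atom. The large earlier gap narrows but does not close, with a 2.4-fold lower number from compound 1 to compound 3 (0.39 log units; beyond the scatter) still left between the two. Nothing at hand accounts for this rise.

On these data alone, whether fluoro, bromo or methyl on the same carbon would match chloro remains open. So does whether chloro on another carbon of this ring would give a similar step.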